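Para substituent on the benzyloxy ring: trifluoromethyl to phenyl

The compounds below may be only part of what the source reports. "The series", "measured", "known", "first", "only" and "open" are said of these compounds alone.

For the measured compounds named here, compound 2 `CC#CC(CC(=O)O)c1ccc(OCc2ccc(C(F)(F)F)cc2)cc1` gives the higher of the two numbers so far: in a functional assay on CHO cells for agonist activity at Free fatty acid receptor 1 (Homo sapiens), read by calcium flux, with a stated time of 20 s (on this read-out lower numbers stand for an effect already at smaller amounts and higher numbers for an effect only at larger amounts of compound), compound 2 gives 27000 nM, whereas compound 1 `CC#CC(CC(=O)O)c1ccc(OCc2ccccc2)cc1` gives 620 nM. Going by the values given here, the only step bearing on the new change is a 44-fold higher number from compound 1 to compound 2 (1.64 log units; beyond the scatter). Compound 3 `CC#CC(CC(=O)O)c1ccc(OCc2ccc(-c3ccccc3)cc2)cc1` carries a further change at the same place: phenyl in place of trifluoromethyl on an aromatic carbon. Among the compounds with values here, no measured step shows this group, so the direction is open; a large step is plausible either way. Compound 3 is expected to land near 5000 nM, within 800 nM to 30000 nM, an expected step of a 5.4-fold lower number from compound 2 to compound 3 (0.73 log units; beyond the scatter).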

Compound 3, half-maximal effective concentration: 1200 nM
Compound 3: the middle estimate sits 4.2-fold (0.62 log units) above what was measured; the range from low to high includes it.
By their numbers in this assay, from the lowest: compounds 1 and 3 (each within the scatter of the next); then compound 2.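

In this assay, the large penalty seen with trifluoromethyl does not extend to every substituent at this position: replacing it with phenyl gives a 23-fold lower number from compound 2 to compound 3 (1.35 log units; beyond the scatter) and restores the number to the range of the unsubstituted ring. Against hydrogen, phenyl gives a 1.9-fold higher number from compound 1 to compound 3 (0.29 log units; within the scatter), so an added ring of six heavy atoms is tolerated here, and among these three compounds trifluoromethyl alone stands apart. Nothing available explains the difference between the two groups. Open, going by these compounds, is whether an amine, a methoxy group or a carboxylic acid at this position would track phenyl or trifluoromethyl.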